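Cyclopentyl for 2-fluorophenyl on the amine nitrogen

The source may hold more compounds than are shown below. What is called first, only, known or untested is meant among the compounds shown, and "the series" means these compounds.

In a functional assay on MCF7 cells (Homo sapiens) for inhibition, read by sulforhodamine B assay (a lower number here means a stronger inhibitor, a higher number a weaker inhibitor), compound 1 `CCCc1ccc(NC2=CC(=O)c3nc4n(c3C2=O)[C@H]2OC[C@@H](O)[C@H]2OC4)cc1` gives 4660 nM. Compound 2 `O=C1C=C(NCc2ccccc2)C(=O)c2c1nc1n2[C@H]2OC[C@@H](O)[C@H]2OC1` stands at > 8000 nM, which is a limit. Compound 3 `O=C1C(Nc2ccccc2F)=CC(=O)c2c1nc1n2[C@H]2OC[C@@H](O)[C@H]2OC1` stands at > 4000 nM, which is also a limit and not a number. Compound 4 `O=C1C(NC2CCCC2)=CC(=O)c2c1nc1n2[C@H]2OC[C@@H](O)[C@H]2OC1` carries cyclopentyl in place of 2-fluorophenyl on an amine nitrogen. Among the compounds with values here, the only measured step that bears on this change is an at least 1.7-fold higher number from compound 1 to compound 2 (0.23 log units; that floor lies within the scatter), so the size of a change at this nitrogen remains open. No shift beyond the scatter is therefore expected in this assay, and no direction can be assigned. The estimated move is a step that the limit leaves unreadable from compound 3 to compound 4. For compound 4 the expected value is 6000 nM, with an estimated range of 2500 nM to 15000 nM.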

Compound 4, half-maximal inhibitory concentration: > 16000 nM
Compound 4: a limit, no number; the forecaster's own chance of this, stated with the estimate: 60%; middle value at least 2.6-fold (0.42 log units) from the limit.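

In this assay, compound 3 and compound 4 both stand only at limits, so the step between them cannot be read. On these data alone, whether cyclopentyl or 2-fluorophenyl on the amine nitrogen gives the stronger inhibitor stays open.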